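The compounds below may be only part of what the source reports. "The series", "measured", "known", "first", "only" and "open" are said of these compounds alone.

Measured so far:
compound 1 `NC(=S)N1CCc2c(OCCCCCOc3ccc(Cl)cc3)cccc21`: > 50000 nM
compound 2 `O=C(NC(=S)N1CCc2c(OCCCCCOc3ccc(Cl)cc3)cccc21)c1ccc(Cl)cc1`: 21700 nM

In an ADME assay on Huh-7 cells (Homo sapiens) for cytotoxicity (on this read-out higher numbers stand for lower toxicity in this test and lower numbers for higher toxicity in this test), compound 1 gives > 50000 nM, which is a limit of the assay and not a number. Going by the values given here, compound 2 gives 21700 nM, the only number among the two values shown. Among the compounds with values here, the single measured step, an at least 2.3-fold lower number from compound 1 to compound 2 (0.36 log units; beyond the scatter), rests on (the limit of > 50000 nM in this assay, at which 1 of the 2 values shown sits). Compound 3 `O=C(NC(=S)N1CCc2c(OCCCCCOc3ccc(Cl)cc3)cccc21)c1ccc(Br)cc1` differs from compound 2 by bromo in place of chloro on an aromatic carbon. Within the data shown here, no measured step exchanges one halogen for another, so the step to compound 3 is expected to stay within the scatter, a 1.1-fold lower number from compound 2 to compound 3 (0.04 log units; within the scatter). Compound 3 is therefore estimated at 20000 nM, between 10000 nM and 40000 nM.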

Compound 3, half-maximal cytotoxic concentration: 29100 nM
Estimate against measurement, compound 3: 1.5-fold (0.16 log units) below, within the range that was stated.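

In this assay, the change from 4-chlorophenyl to 4-bromophenyl gives a 1.3-fold higher number from compound 2 to compound 3 (0.13 log units; within the scatter) and so, at this place para to a large group, does not separate the two halogens. The other step, an at least 1.7-fold lower number from compound 1 to compound 3 (0.23 log units; that floor lies within the scatter), gives only a floor, does not show that compound 3 differs from compound 1, and rests on a limit of the assay: the limit of > 50000 nM in this assay, at which 1 of the 3 values shown sits. Going by these compounds, whether a methoxy or a carboxylic acid in place of the halogen would shift the number stays open, as does the effect of a longer chain on the shared core.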